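The source may report more compounds than this note shows. Statements on the series, on what has been measured and on what is new or still open speak of the compounds shown alone.

Measured compounds:
compound 1, `COc1cc(C(=O)/C=C/c2ccc(O)c(O)c2)ccc1O`, 9 nM
compound 2, `COc1ccc(C(=O)/C=C/c2ccc(O)c(O)c2)cc1OC`, 18 nM
compound 3, `CCOc1ccc(O)c(C(=O)/C=C/c2ccc(O)c(O)c2)c1`, 5.3 nM

In an assay on RBL-1 cells for inhibition of Polyunsaturated fatty acid 5-lipoxygenase (Rattus norvegicus) (on this read-out higher numbers stand for weaker inhibition and lower numbers for stronger inhibition), compound 1 gives 9 nM, and compound 2, which carries the change (methyl in place of hydrogen on an oxygen on an aromatic ring), gives 18 nM. That change made the step of a 2.0-fold higher number from compound 1 to compound 2 (0.30 log units; within the scatter). Compound 3 gives 5.3 nM in this assay; the difference between the cores of compound 1 and compound 3 is not broken down here. Compound 4, `CCOc1ccc(OC)c(C(=O)/C=C/c2ccc(O)c(O)c2)c1`, is not yet measured. It differs from compound 3 by methyl in place of hydrogen on an oxygen on an aromatic ring, the same change as that from compound 1 to compound 2, at a place whose surroundings read the same in both pairs. Among the measured compounds shown here, the step from compound 3 to compound 4 in this assay is therefore expected to be a 2.1-fold higher number from compound 3 to compound 4 (0.32 log units; beyond the scatter), resting on the single earlier step of a 2.0-fold higher number from compound 1 to compound 2 (0.30 log units; within the scatter). Compound 4 is estimated to give 11 nM in this assay, with a range from 4 nM to 30 nM.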

Compound 4, half-maximal inhibitory concentration: 3.8 nM
The estimate for compound 4 lay 2.9-fold (0.46 log units) above the measured number, and the stated range ends above it.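

In this assay, methyl in place of hydrogen on the oxygen on the aromatic ring gave a 1.4-fold lower number from compound 3 to compound 4 (0.14 log units; within the scatter). Set beside the earlier step, the same change did not carry over from one core to the other at the same size: the same change on two cores in this assay, a 2.0-fold higher number (0.30 log units; within the scatter) from compound 1 to compound 2 and a 1.4-fold lower number (0.14 log units; within the scatter) from compound 3 to compound 4, 2.8-fold (0.45 log units) apart, beyond the scatter of two such steps. With a single pair on each core, this shows that the step seen on the core of compound 1 was a poor guide on the core of compound 3, but it does not show why the two steps part or how the change would behave on any further core.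

The compounds shown leave open how a longer chain or an amine on that oxygen would read in this assay. They also leave open whether the change from hydroxy to methoxy on a third core would follow either step.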